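A few compounds are considered here, and "the series" means these few. Any claim that something is new, unique, unknown or untested is made for them only; others in the source may bear on it.

Of the compounds shown here, three of one shared core have been measured in a functional assay (muscle tissue) with Cavia porcellus as the target; a higher number here means a weaker inhibitor, a lower number a stronger inhibitor. Compound 1 `CO/C(O)=C1/C(C)=NC(C)=C([N+](=O)[O-])C1c1cccc(C)n1` gives 2290 nM. Compound 2 `CC1=NC(C)=C([N+](=O)[O-])C(c2cccc(C)n2)/C1=C(/O)OCCc1ccccc1` gives 9980 nM, and compound 3 `CC1=NC(C)=C([N+](=O)[O-])C(c2ncccc2C)/C1=C(/O)OCCc1ccccc1` gives 5430 nM. Of these three numbers, that of compound 2 is the largest; the gap to compound 3 stays within the scatter, while only the gap to compound 1 lies beyond it. The step of a 4.4-fold higher number from compound 1 to compound 2 (0.64 log units; beyond the scatter) was modest, and the step of a 1.8-fold lower number from compound 2 to compound 3 (0.26 log units; within the scatter) was within the scatter.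

Compound 4 `CC1=NC(C)=C([N+](=O)[O-])C(c2cccc(-c3ccccc3)n2)/C1=C(/O)OCCc1ccccc1` differs from compound 2 in one place: phenyl in place of methyl on an aromatic carbon. Neither measured step touches the same place. The step from compound 2 to compound 3, which alters the same six-membered aromatic ring with 1 nitrogen, was within the scatter, and the step from compound 1 to compound 2 altered a different part. Nothing in these steps points to a large change in this assay in either direction, so the expected step of a 1.1-fold lower number from compound 2 to compound 4 (0.04 log units; within the scatter) stays within the scatter. Compound 4 is therefore estimated at 9000 nM, with a range from 2500 nM to 30000 nM.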

Compound 4, half-maximal inhibitory concentration: 8380 nM
The estimate for compound 4 lay 1.1-fold (0.03 log units) above the measured number; low and high end bracket the measured number.
By their numbers in this assay, from the lowest: compound 1; then compounds 3, 4 and 2 (each within the scatter of the next).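

In this assay, the aromatic carbon next to the ring nitrogen takes phenyl, with 6 heavy atoms and a ring of its own, in place of methyl, with 1 heavy atom, and the outcome is a 1.2-fold lower number from compound 2 to compound 4 (0.08 log units; within the scatter). Going by these compounds alone, the earlier compounds carried only a methyl on this ring, so this is the first sign that this carbon can hold a much larger group of carbon only without a clear shift in the number. No measurement shown here explains why the number holds steady across this change. Still open, going by these compounds, is whether a group that is not pure hydrocarbon at this carbon, such as an amine or a carboxylic acid, would shift the number. Also open, on these data alone, is whether phenyl here gives an equally small step on compound 1, which lacks the benzyl group.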